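The source may hold more compounds than are shown below. What is called first, only, known or untested is meant among the compounds shown, and "the series" means these compounds.

Of the compounds shown here, three have already been measured in an assay on CHO cells for displacement of a labelled ligand from prostaglandin E2 receptor EP1 subtype (Homo sapiens); a lower number here means a stronger inhibitor, a higher number a weaker inhibitor. Compound 1 `CCc1ccccc1N(CC(=O)OCc1ccc(OC)cc1)S(=O)(=O)c1ccc(C)cc1` was tested more than once, and in this assay compound 1 gives 63 nM; 63.1 nM (2 entries); the agreement between its repeats the several entries of compound 1 in this assay, 63 nM; 63.1 nM (2 entries) shows how steady the readout can be. Compound 3 `CCc1ccccc1N(Cc1nnc(Oc2ccc(OC)cc2)o1)S(=O)(=O)c1ccc(C)cc1` has only a limit of the assay rather than a number: in this assay compound 3 gives < 1000 nM, a boundary at which one of the three values sits (the limit of < 1000 nM in this assay, at which 1 of the 3 values shown sits). Going by the values given here, compound 2 `Cc1ccc(S(=O)(=O)N(Cc2nnc(Cc3ccc(F)cc3)o2)c2cccc(Cl)c2C)cc1` is therefore the only member with a single measured number, and in this assay compound 2 gives 200 nM.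

The next compound, compound 4 `COc1ccc(NCc2nnc(CN(c3cccc(Cl)c3C)S(=O)(=O)c3ccc(C)cc3)o2)cc1`, has not yet been measured. It differs from compound 2 in one place: (4-methoxyphenyl)amino in place of 4-fluorophenyl on a saturated chain carbon bound to an aromatic carbon. Among the compounds with values here, no measured pair in this set carries the same change, so there is nothing to show how large a shift it brings. With that in mind, the step from compound 2 to compound 4 is expected to be small, a 1.5-fold higher number from compound 2 to compound 4 (0.18 log units; within the scatter), and to stay within the usual scatter rather than move clearly in either direction. Compound 4 is accordingly estimated at 300 nM, with a plausible range from 80 nM to 1200 nM.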

Compound 4, half-maximal inhibitory concentration: 20 nM
For compound 4 the middle estimate is 15-fold (1.18 log units) above the measured one, and the stated range ends above it.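

In this assay, placing (4-methoxyphenyl)amino where 4-fluorophenyl stood gives a 10-fold lower number from compound 2 to compound 4 (1.00 log units; beyond the scatter). Going by these compounds alone, this shows what no earlier pair could: a change on this saturated chain carbon bound to an aromatic carbon can move the number clearly, and here the move is towards a stronger inhibitor. The step is also more likely a real shift than noise, since repeated entries for one compound can agree closely: the several entries of compound 1 in this assay, 63 nM; 63.1 nM (2 entries)

The step changes several things at once, as the entering group brings both a nitrogen and an oxygen and adds a hydrogen-bond donor and hydrogen-bond acceptors, so the compounds shown leave open which part carries the shift. A plain phenylamino group or a (4-fluorophenyl)amino group at the same place would help separate the amino link from the methoxy group, and a carboxylic acid in place of that methoxy group would test how far this position can be pushed.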